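Swapping the amine for a thioether on compound 3's pyridine

A few compounds are considered here, and "the series" means these few. Any claim that something is new, unique, unknown or untested is made for them only; others in the source may bear on it.

Measured compounds:
`CS(=O)(=O)Nc1ccc(C(C(=O)NCc2ccc(C(F)(F)F)nc2SC2CCCCC2)C2CCCC2)cc1F` compound 1, 103 nM
`CS(=O)(=O)Nc1ccc(C(C(=O)NCc2ccc(C(F)(F)F)nc2SC2CCCCC2)c2ccc(F)cc2)cc1F` compound 2, 37.6 nM
`Cc1ccc(C(C(=O)NCc2ccc(C(F)(F)F)nc2N2CCC(C)CC2)c2ccc(NS(C)(=O)=O)c(F)c2)cc1` compound 3, 1.1 nM

In an assay on CHO cells for antagonist activity at transient receptor potential cation channel subfamily V member 1 (Homo sapiens), read by FLIPR (a higher number here means a weaker inhibitor, a lower number a stronger inhibitor), compound 3 gives the lowest of the three numbers; compound 2 comes nearest with a number beyond the scatter above it, and compound 1 lies furthest away, also beyond the scatter. Compound 4, `Cc1ccc(C(C(=O)NCc2ccc(C(F)(F)F)nc2SC2CCCCC2)c2ccc(NS(C)(=O)=O)c(F)c2)cc1`, is not yet measured. It differs from compound 3 in one place: cyclohexylsulfanyl in place of 4-methylpiperidin-1-yl on an aromatic carbon.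

Going by the values given here, none of the measured steps bears directly on this change. Among the compounds with values here, the only measured step, a 2.7-fold lower number from compound 1 to compound 2 (0.44 log units; beyond the scatter), concerns the saturated chain carbon and leaves the cyclohexylsulfanyl group untouched, so it says nothing about the exchange in hand. Compounds 1 and 2 carry cyclohexylsulfanyl, but they also differ from compound 3 at the chain carbon, so their values and the value of compound 3 cannot be separated into the two changes. What the numbers show is that both cyclohexylsulfanyl compounds sit well above compound 3.

On that thin basis, a modest weakening is expected in this assay from compound 3 to compound 4, a 3.2-fold higher number from compound 3 to compound 4 (0.50 log units; beyond the scatter). Compound 4 is estimated at 3.5 nM, with a range from 0.9 nM to 14 nM.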

Compound 4, inhibition constant: 7.5 nM
For compound 4 the middle estimate is 2.1-fold (0.33 log units) below the measured one; the measured number falls inside the stated range.
By their numbers in this assay, from the lowest: compound 3; then compound 4; then compound 2; then compound 1.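

In this assay, going by these compounds alone, exchanging 4-methylpiperidin-1-yl for cyclohexylsulfanyl on the aromatic carbon next to the ring nitrogen gives a 6.8-fold higher number from compound 3 to compound 4 (0.83 log units; beyond the scatter), which isolates this change for the first time and shows that the position distinguishes two groups of 7 heavy atoms each, one entering through sulfur and the other through nitrogen. With cyclohexylsulfanyl held in place, methyl in place of fluoro on an aromatic carbon gives a 5.0-fold lower number from compound 2 to compound 4 (0.70 log units; beyond the scatter), and 4-methylphenyl in place of cyclopentyl on the saturated chain carbon gives a 14-fold lower number from compound 1 to compound 4 (1.14 log units; beyond the scatter), so cyclohexylsulfanyl accounts for only part of the distance of compound 1 and compound 2 from compound 3. The data offer no explanation for the size of any of these steps.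

The compounds shown leave open how a cyclohexyloxy group or an unsubstituted piperidin-1-yl would compare at this position, and so whether the sulfur, the nitrogen or the methyl on the ring matters most. They also leave open whether the step between 4-methylpiperidin-1-yl and cyclohexylsulfanyl would keep its size with 4-fluorophenyl or cyclopentyl on the chain carbon.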